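The compounds below may be only part of what the source reports. "The series", "measured", "known", "first", "only" and "open" are said of these compounds alone.

Measured compounds:
compound 1, `CN(C)C(=S)N/N=C/c1ccc2cccnc2n1`, 630 nM in a functional assay on SGC-7901 cells (Homo sapiens) for antiproliferative activity, read by sulforhodamine B assay, with a stated time of 72 h; a lower number here means a stronger inhibitor, a higher number a weaker inhibitor
compound 2, `S=C(N/N=C/c1ccc2ccccc2n1)Nc1cccc(Br)c1`, 78600 nM in this assay
compound 3, `NC(=S)N/N=C/c1nc2ccccc2s1`, a limit of the assay, > 100000 nM in this assay

Compound 2 stands at the highest of the two numbers in this assay, and the nearest number, that of compound 1, is far lower, well beyond the scatter. Compound 3 is reported only as a limit, (the limit of > 100000 nM in this assay, at which 1 of the 3 values shown sits), and so gives no number to compare.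

Compound 4, `Fc1cccc(NC(=S)N/N=C/c2ccc3ccccc3n2)c1`, is compound 2 with one change: fluoro in place of bromo on an aromatic carbon. The bromine leaves and a fluorine enters at the same position; the 3-bromophenyl becomes a 3-fluorophenyl. Nothing in the measured set shows what such an exchange does in this assay, so no size or direction can be read from the data. The expected step from compound 2 to compound 4 in this assay is therefore a 1.1-fold higher number from compound 2 to compound 4 (0.03 log units; within the scatter), that is, none beyond the scatter. Compound 4 is estimated at 85000 nM in this assay, with a range of 30000 nM to 200000 nM.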

Compound 4, half-maximal inhibitory concentration: 79900 nM
For compound 4 the middle estimate is 1.1-fold (0.03 log units) above the measured one, within the range that was stated.
By their numbers in this assay, from the lowest: compound 1; then compounds 2 and 4 (each within the scatter of the next). At a limit, above all of these: compound 3.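

In this assay, going by these compounds alone, the exchange of bromo for fluoro on this aromatic carbon, meta to a large group, is the first single change that can be read, and it gives a 1.0-fold higher number from compound 2 to compound 4 (0.01 log units; within the scatter). The 3-bromophenyl and 3-fluorophenyl compounds therefore cannot be told apart here, so at this position the choice between these two halogens makes no difference that the assay can detect. Compound 3 alone is reported as a limit of the assay, while compound 2 and compound 4 both carry true numbers: the limit of > 100000 nM in this assay, at which 1 of the 4 values shown sits.

From the compounds shown here alone, whether a group other than a halogen at this position, such as an amine, a methoxy group or a carboxylic acid, would shift the number remains open. Also open, going by these compounds, is what the same exchange would do elsewhere on that ring, and what the bare phenyl ring would give.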